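The source may report more compounds than this note shows. Statements on the series, on what has been measured and on what is new or still open speak of the compounds shown alone.

Measured in a functional assay on A549 cells (Homo sapiens) for antiproliferative activity, read by MTT assay; on this read-out lower numbers stand for stronger inhibition and higher numbers for weaker inhibition:
Compound 1 `COc1cc2c(Oc3ccc(NC(=O)Nc4ccc(OC(F)(F)F)cc4)cc3)ccnc2cc1OCCCCCCC(=O)NO`: 3130 nM
Compound 2 `COc1cc2c(Oc3ccc(NC(=O)NNC(=O)c4ccccc4)cc3)ccnc2cc1OCCCCCCC(=O)NO`: 2820 nM

Going by the values given here, compound 2, at 2820 nM, stands level with compound 1, the only other compound measured. Compound 3 `COc1cc2c(Oc3ccc(NC(=O)NNC(=O)c4ccccc4F)cc3)ccnc2cc1OCCCCCCC(=O)NO` differs from compound 2 by one change: fluoro in place of hydrogen on an aromatic carbon. This is fluoro in place of hydrogen on an aromatic carbon, ortho to a large group, turning benzoyl into (2-fluorophenyl)carbonyl. Among the compounds with values here, the data hold no measured step at this ring position. Within the data shown here, the one step available, a 1.1-fold lower number from compound 1 to compound 2 (0.05 log units; within the scatter), put benzamido in place of 4-(trifluoromethoxy)phenyl on an amide-type nitrogen, so it bears on the new change only loosely. On the strength of that step between compound 1 and compound 2, no shift beyond the scatter is expected in this assay, in either direction. The expected change is a 1.0-fold lower number from compound 2 to compound 3 (0.02 log units; within the scatter). Compound 3 is estimated at 2700 nM, with an expected range of 1200 nM to 5500 nM.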

Compound 3, half-maximal inhibitory concentration: 2420 nM
Estimate against measurement, compound 3: 1.1-fold (0.05 log units) above; measured number inside the range.
By their numbers in this assay, from the lowest: compounds 3, 2 and 1 (each within the scatter of the next).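

In this assay the aromatic carbon ortho to a large group now has its first measured step: fluoro in place of hydrogen gives a 1.2-fold lower number from compound 2 to compound 3 (0.07 log units; within the scatter) and so does not move the number beyond the scatter. The ((2-fluorophenyl)carbonyl)amino group also stands level with the 4-(trifluoromethoxy)phenyl group on the amide-type nitrogen, with a 1.3-fold lower number from compound 1 to compound 3 (0.11 log units; within the scatter) for that exchange. Nothing measured on these compounds bears on the reason for this result.

The compounds shown leave open whether a chloro group, a methoxy group or an amine on this same carbon would shift the number beyond the scatter. Also open, from the compounds shown here alone, is whether fluoro on another carbon of that ring, or a longer chain ending in the hydroxamic acid, would do so.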